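The source may report more compounds than this note shows. Statements on the series, on what has been measured and on what is new or still open speak of the compounds shown alone.

Working notes on the series. In a functional assay on MCF-A cells (Homo sapiens) for cytotoxicity (on this read-out higher numbers stand for weaker inhibition of growth and lower numbers for stronger inhibition of growth), compound 1 (`CSc1ccc(C2=C(c3ccc(O)c(O)c3)C(=O)N3CCCC3C2)cc1`) gives 80000 nM and compound 2 (`CSc1ccc(C2=C(c3ccc(Br)cc3)C(=O)N3CCCC3C2)cc1`) gives 8000 nM. For the measured compounds named here, compound 2 therefore holds the lower of the two numbers, with compound 1 as its only neighbour.

The next compound is compound 3 (`CSc1ccc(C2=C(c3ccc(SC)cc3)C(=O)N3CCCC3C2)cc1`). It differs from compound 2 by methylsulfanyl in place of bromo on an aromatic carbon, para to a large group: methylsulfanyl in place of bromo on an aromatic carbon.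

Going by the values given here, only one measured step bears on this change: a 10-fold lower number from compound 1 to compound 2 (1.00 log units; beyond the scatter), with 4-bromophenyl in place of 3,4-dihydroxyphenyl on a double-bonded ring carbon. That step is modest but beyond the scatter, and it alters the same aryl group. Among the compounds with values here, it does not test methylsulfanyl, since no measured compound carries that group at this place. With that single step as the guide, a smaller step is expected in this assay, with no firm direction and probably none beyond the scatter.

The expected change is a 1.3-fold higher number from compound 2 to compound 3 (0.10 log units; within the scatter). For compound 3 the estimate is 10000 nM, with an expected range from 3000 nM to 35000 nM.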

Compound 3, concentration for 50% growth inhibition: 8000 nM
For compound 3 the middle estimate is 1.3-fold (0.10 log units) above the measured one; the range from low to high includes it.
By their numbers in this assay, from the lowest: compounds 2 and 3 (each within the scatter of the next); then compound 1.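

In this assay, methylsulfanyl in place of bromo on an aromatic carbon, para to a large group, gives no change at the digits printed from compound 2 to compound 3 (within the scatter), so the two groups cannot be told apart at this place in this read-out, although their heavy-atom and acceptor counts differ. Replacing 3,4-dihydroxyphenyl with 4-(methylsulfanyl)phenyl gives a 10-fold lower number from compound 1 to compound 3 (1.00 log units; beyond the scatter), a step of the same size as a 10-fold lower number from compound 1 to compound 2 (1.00 log units; beyond the scatter), so the lower number is no longer tied to bromo alone and is now seen with two different groups on the phenyl ring. No measurement at hand gives a cause for this result.

From the compounds shown here alone, whether the same flat response would hold for an amine, a carboxylic acid or a longer chain such as butylsulfanyl at this place remains open. Also open, going by these compounds, is whether a single hydroxy group on the phenyl ring would give numbers closer to those of compound 1 or to those of compound 2 and compound 3, since only the dihydroxy form stands.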